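Anilino pyranone series: cyclohexyl for phenyl on the nitrogen

This account rests on a few compounds, and the source may have more. Where it says the series, first, only, none or still open, it means among the compounds named here.

Measured so far: compound 1 `COc1cccc(Nc2cc(-c3ccccc3)oc(=O)c2)c1` 0.74 uM; compound 2 `O=c1cc(Nc2ccccc2)cc(-c2ccccc2)o1` 0.13 uM; compound 3 `COc1ccc(Nc2cc(-c3ccccc3)oc(=O)c2)cc1` 0.079 uM, all in a functional assay on SK-BR-3 cells (Homo sapiens) for cytotoxicity, read by MTT assay, with a stated time of 72 h; on this read-out lower numbers stand for an effect already at smaller amounts and higher numbers for an effect only at larger amounts of compound.

Compound 2 holds the second highest number of the three. Compound 3 sits nearest, a 1.6-fold lower number from compound 2 to compound 3 (0.22 log units; within the scatter); compound 1 is furthest, a 5.7-fold lower number from compound 1 to compound 2 (0.76 log units; beyond the scatter). Compound 4 `O=c1cc(NC2CCCCC2)cc(-c2ccccc2)o1` has not been measured. It differs from compound 2 by cyclohexyl in place of phenyl on a nitrogen on an aromatic ring. Both measured steps concern a methoxy placed on, or removed from, the phenyl carried by the nitrogen; none replaces that phenyl itself. Going by the values given here, no measured step therefore bears on this change, and the expectation rests on compound 2 alone with wide uncertainty. Compound 4 is expected near 0.4 uM, within 0.08 uM to 2 uM, which means a step of a 3.1-fold higher number from compound 2 to compound 4 (0.49 log units; beyond the scatter) in this assay.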

Compound 4, concentration for half-maximal effect: 10.9 uM
Compound 4: middle estimate off by 27-fold (1.44 log units), on the low side, outside the stated range (above it).
By their numbers in this assay, from the lowest: compounds 3 and 2 (each within the scatter of the next); then compound 1; then compound 4.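

Cyclohexyl in place of phenyl on the nitrogen gives an 84-fold higher number from compound 2 to compound 4 (1.92 log units; beyond the scatter) in this assay, so this position, which the methoxy steps had probed only through substitution on the phenyl, proves highly sensitive to replacement of the ring itself. Both groups have the same heavy-atom count, and the printed difference is an aromatic versus a non-aromatic ring of carbon. Nothing measured here accounts for the step.

On these data alone, whether a benzyl or pyridyl on the nitrogen would keep the lower numbers of compound 2 remains open. An open chain such as n-butyl is equally undecided.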